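This account rests on a few compounds, and the source may have more. Where it says the series, first, only, none or still open, it means among the compounds named here.

Compound 1 `NC(=O)c1c(NC(=O)c2ccccc2Cl)sc2c1CCN(Cc1ccccc1)C2` and compound 2 `NC(=O)c1c(NC(=O)c2ccccc2Cl)sc2c1CCN(C(=S)Nc1ccccc1I)C2` share one core and differ only in the group carried on an amine nitrogen in a ring. In a functional assay on HL-60 cells (Homo sapiens) for antiproliferative activity, with a stated time of 24 h (a lower number here means a stronger inhibitor, a higher number a weaker inhibitor), compound 1 gives 12000 nM, while compound 2 gives 4430 nM. Among the measured compounds shown here, the single measured step between them, a 2.7-fold lower number from compound 1 to compound 2 (0.43 log units; beyond the scatter), is modest but beyond the scatter. Compound 2 therefore stands at the lowest of the two numbers, with compound 1 as its nearest neighbour at a higher number.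

Compound 3 `COc1ccccc1NC(=S)N1CCc2c(sc(NC(=O)c3ccccc3Cl)c2C(N)=O)C1` has not yet been measured in this assay. It differs from compound 2 by methoxy in place of iodo on an aromatic carbon. For the measured compounds named here, no measured step bears on this particular change: the step from compound 1 to compound 2 concerns the group on the amine nitrogen in the ring, not a substituent on the six-membered aromatic ring of carbon. Going by the values given here, with nothing among the measured compounds to anchor a direction, no step beyond the scatter is expected in this assay. The expected step is a 1.0-fold lower number from compound 2 to compound 3 (0.00 log units; within the scatter). Compound 3 is accordingly estimated at 4400 nM, with a range from 1500 nM to 13000 nM.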

Compound 3, half-maximal inhibitory concentration: 40900 nM
Estimate against measurement, compound 3: 9.3-fold (0.97 log units) below; measured number outside the range, above it.
By their numbers in this assay, from the lowest: compound 2; then compound 1; then compound 3.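

In this assay, the aromatic carbon ortho to a large group proves to be a position that responds strongly to its substituent: methoxy in place of iodo gives a 9.2-fold higher number from compound 2 to compound 3 (0.97 log units; beyond the scatter) and cancels the advantage that compound 2 held. The earlier pair could not show this, since it spoke only to the group on the ring amine nitrogen, and its step, a 2.7-fold lower number from compound 1 to compound 2 (0.43 log units; beyond the scatter), suggested that the larger group there was an improvement. That reading now depends on the substituent on the aromatic ring, for the change on the same nitrogen that carries the 2-methoxyphenyl group gives a 3.4-fold higher number from compound 1 to compound 3 (0.53 log units; beyond the scatter) and so runs in the opposite direction; nothing available explains why the two substituents differ so widely.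

The compounds shown leave open where a methyl, a chloro or an amine on the same aromatic carbon would fall relative to iodo and methoxy, and where the ring without any substituent would stand. They also leave open whether iodo and methoxy would keep this order on another carbon of that ring.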